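Urea aryl swaps on the shared core

The source may report more compounds than this note shows. Statements on the series, on what has been measured and on what is new or still open speak of the compounds shown alone.

Measured in a functional assay on MGC-803 cells (Homo sapiens) for antiproliferative activity, read by MTT assay, with a stated time of 48 h; on this read-out lower numbers stand for stronger inhibition and higher numbers for weaker inhibition:
Compound 1, `CN(C)c1ccc(NC(=O)Nc2cccc(CNc3nccnc3Cl)c2)cc1`: compound 1 gives 11500 nM.
Compound 2, `O=C(Nc1cccc(CNc2nccnc2Cl)c1)Nc1ccc(F)c(Cl)c1`: compound 2 gives 5020 nM.
Compound 3, `CCc1ccccc1NC(=O)Nc1cccc(CNc2nccnc2Cl)c1`: compound 3 gives 9370 nM.

Compound 1 stands highest of the three numbers. Nearest to it is compound 3, with a 1.2-fold lower number from compound 1 to compound 3 (0.09 log units; within the scatter); furthest is compound 2, with a 2.3-fold lower number from compound 1 to compound 2 (0.36 log units; beyond the scatter). Between the other two the gap, a 1.9-fold higher number from compound 2 to compound 3 (0.27 log units; within the scatter), stays within the scatter, so no order can be read between compound 2 and compound 3.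

Compound 4, `Cc1ccc(NC(=O)Nc2cccc(CNc3nccnc3Cl)c2)cc1C`, has not yet been measured. It differs from compound 1 at the same position that the two measured steps touch: 3,4-dimethylphenyl in place of 4-(dimethylamino)phenyl on an amide-type nitrogen. Both known replacements of the 4-(dimethylamino)phenyl gave a lower or unchanged number; the substituted phenyl entering here resembles in kind the 3-chloro-4-fluorophenyl of compound 2 more than the 2-ethylphenyl of compound 3, which points toward the modest lowering seen in a 2.3-fold lower number from compound 1 to compound 2 (0.36 log units; beyond the scatter) rather than the flat result of a 1.2-fold lower number from compound 1 to compound 3 (0.09 log units; within the scatter). The step is therefore expected to be a 1.6-fold lower number from compound 1 to compound 4 (0.22 log units; within the scatter), with a within-scatter outcome still possible. Compound 4 is expected at 7000 nM, with a range from 3500 nM to 14000 nM.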

Compound 4, half-maximal inhibitory concentration: 9870 nM
Compound 4: middle estimate off by 1.4-fold (0.15 log units), on the low side; the measured number falls inside the stated range.
By their numbers in this assay, from the lowest: compounds 2, 3, 4 and 1 (each within the scatter of the next, the first and the last beyond it).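

In this assay, 3,4-dimethylphenyl in place of 4-(dimethylamino)phenyl on the amide-type nitrogen stays within the scatter, a 1.2-fold lower number from compound 1 to compound 4 (0.07 log units; within the scatter), so a group with 0 hydrogen-bond acceptors in place of one with 1 gives no readable difference in this pair. The other two new steps, a 1.1-fold higher number from compound 3 to compound 4 (0.02 log units; within the scatter) and a 2.0-fold higher number from compound 2 to compound 4 (0.29 log units; within the scatter), are also within the scatter, so the 3,4-dimethylphenyl group cannot be ranked against either the 2-ethylphenyl or the 3-chloro-4-fluorophenyl group, and the comparison with the last of these does not show that the two groups behave alike. No evidence is at hand that would explain these numbers.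

The only step beyond the scatter at this position remains a 2.3-fold lower number from compound 1 to compound 2 (0.36 log units; beyond the scatter), and with a single halogen-bearing group among the compounds shown, it stays open whether that separation is tied to the chlorine and fluorine substituents or to that one group alone. All the groups shown on this nitrogen are substituted phenyl groups with small substituents, so the effect of a carboxylic acid, an amine on a longer chain, or a longer alkyl chain on the phenyl group remains open.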